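The source may report more compounds than this note shows. Statements on the series, on what has been measured and on what is new or still open speak of the compounds shown alone.

In an assay on H4 cells for inhibition of Fatty-acid amide hydrolase 1 (Homo sapiens) (on this read-out lower numbers stand for stronger inhibition and higher numbers for weaker inhibition), compound 3 `CCCCCCOc1ccc(NC(=O)ON=C(C)C)cc1` gives 18 nM, the highest of the three numbers in hand. Compound 1 `CCCCOc1ccc(C(CC)NC(=O)Oc2ccc(F)cc2)cc1` gives 12 nM, within the scatter of compound 3; compound 2 `CCCCOc1ccc(CNC(=O)Oc2ccc(F)cc2)cc1` gives 4.6 nM, beyond it. Among the compounds with values here, the one measured step, a 2.6-fold lower number from compound 1 to compound 2 (0.42 log units; beyond the scatter), concerns a saturated chain carbon bound to an amide-type nitrogen and an aromatic carbon, a site not touched by the present change. Compound 4 `CCCCCCCCCCCCOc1ccc(NC(=O)ON=C(C)C)cc1` differs from compound 3 by hexyl in place of hydrogen on a saturated chain carbon, six bonds along the chain from an oxygen on an aromatic ring. Within the data shown here, no measured step bears on this chain, so the expectation rests on compound 3 alone. For compound 4 a step of no change at the digits printed from compound 3 to compound 4 (within the scatter) is expected, none beyond the scatter. Compound 4 is estimated at 18 nM in this assay, range 5 nM to 70 nM.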

Compound 4, half-maximal inhibitory concentration: 5 nM
Estimate against measurement, compound 4: 3.6-fold (0.56 log units) above; measured number inside the range.
By their numbers in this assay, from the lowest: compounds 2 and 4 (each within the scatter of the next); then compounds 1 and 3 (each within the scatter of the next).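

In this assay, within the data shown here, hexyl in place of hydrogen on a saturated chain carbon, six bonds along the chain from an oxygen on an aromatic ring, gives a 3.6-fold lower number from compound 3 to compound 4 (0.56 log units; beyond the scatter) as the first reading on this chain. The position therefore accepts the added hexyl with stronger inhibition, not merely without loss. Nothing on hand explains the step.

On these data alone, with only these two chain lengths, the shape of the trend between them remains open. Also open, as far as these compounds go, is whether a longer chain, or an amine or carboxylic acid in place of hexyl, would hold this level.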